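Chloro on the aromatic ring of the acylthiourea series

A few compounds are considered here, and "the series" means these few. Any claim that something is new, unique, unknown or untested is made for them only; others in the source may bear on it.

Compound 1 `CC(=O)NC(=S)Nc1ccccc1` is the reference of the series. Going by the values given here, in an assay for inhibition of epoxide hydrolase 1 (Homo sapiens), read by fluorescence, using microsomes (on this read-out higher numbers stand for weaker inhibition and lower numbers for stronger inhibition), compound 1 gives 2350 nM, the highest of the three numbers measured so far, and both of its neighbours lie within the scatter of it. Compound 2 `CC(=O)NC(=S)Nc1ccccc1C` gives 1500 nM, a step of a 1.6-fold lower number from compound 1 to compound 2 (0.19 log units; within the scatter). Compound 3 `O=C(NC(=S)Nc1ccccc1)c1ccccc1` gives 1290 nM, a step of a 1.8-fold lower number from compound 1 to compound 3 (0.26 log units; within the scatter).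

Compound 4 `CC(=O)NC(=S)Nc1ccc(Cl)cc1` is not yet measured. Its change from compound 1 is chloro in place of hydrogen on an aromatic carbon. Among the compounds with values here, the only measured change on the aromatic ring of compound 1 is the methyl of compound 2, and that step stayed within the scatter; the change at the carbonyl in compound 3 did likewise. No chloro has been measured in the series, so the expectation can rest only on these two steps, both small.

The expected step is therefore a 1.5-fold lower number from compound 1 to compound 4 (0.17 log units; within the scatter), not beyond the scatter. In this assay compound 4 is estimated at 1600 nM, with a range from 700 nM to 3500 nM.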

Compound 4, half-maximal inhibitory concentration: 2210 nM
Compound 4: middle estimate off by 1.4-fold (0.14 log units), on the low side; the range from low to high includes it.
By their numbers in this assay, from the lowest: compounds 3, 2, 4 and 1 (each within the scatter of the next).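

Chloro, the first halogen in the series, stands on an aromatic carbon para to a group of 7 heavy atoms and gives in this assay a step of a 1.1-fold lower number from compound 1 to compound 4 (0.03 log units; within the scatter). With a 1.6-fold lower number from compound 1 to compound 2 (0.19 log units; within the scatter), there are now two single substitutions on the aromatic ring of compound 1, methyl and chloro, and neither step leaves the scatter. At this place, then, one chlorine atom brings no readable change in inhibition, and no measurement at hand explains that result.

Open, as far as these compounds go, is whether an amine, a carboxylic acid or a longer chain at this place would give a step beyond the scatter. Also open, from the compounds shown here alone, is whether chloro gives an equally small step on the core of compound 3, which carries phenyl at the carbonyl.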